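Exchanging 2,3-dichlorophenyl for 3,4,5-trimethoxyphenyl

The source may hold more compounds than are shown below. What is called first, only, known or untested is meant among the compounds shown, and "the series" means these compounds.

In a functional assay on MCF7 cells (Homo sapiens) for cytotoxicity, read by MTT assay, with a stated time of 72 h (on this read-out lower numbers stand for stronger inhibition and higher numbers for weaker inhibition), compound 1 (`COc1cc(/C=N/NC(=O)Nc2cc3c(Nc4ccc(F)c(Cl)c4)ncnc3cc2O[C@H]2CCOC2)cc(OC)c1OC`) gives 26500 nM. Compound 2 (`COc1cc2ncnc(Nc3ccc(F)c(Cl)c3)c2cc1NC(=O)N/N=C/c1cccc(Cl)c1Cl`) gives 28700 nM, which places the two compounds within the scatter of each other, and neither stands apart on these numbers. Compound 3 (`COc1cc2ncnc(Nc3ccc(F)c(Cl)c3)c2cc1NC(=O)N/N=C/c1cc(OC)c(OC)c(OC)c1`) has not yet been measured. It carries 3,4,5-trimethoxyphenyl in place of 2,3-dichlorophenyl on a carbon with a double bond to nitrogen. Among the measured compounds shown here, no step between measured compounds sizes this exchange directly. For the measured compounds named here, the only guide is compound 1, which bears the same 3,4,5-trimethoxyphenyl group on its own core and gives 26500 nM. No change beyond the scatter is therefore expected in this assay, and the estimated step of a 1.1-fold lower number from compound 2 to compound 3 (0.04 log units; within the scatter) has no clear direction. For compound 3 the estimated value is 26000 nM, with an expected range from 11000 nM to 60000 nM.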

Compound 3, half-maximal inhibitory concentration: 30700 nM
Compound 3: the middle estimate sits 1.2-fold (0.07 log units) below what was measured; measured number inside the range.
By their numbers in this assay, from the lowest: compounds 1, 2 and 3 (each within the scatter of the next).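

In this assay, the exchange of 2,3-dichlorophenyl for 3,4,5-trimethoxyphenyl on a carbon with a double bond to nitrogen can now be sized directly: the step is a 1.1-fold higher number from compound 2 to compound 3 (0.03 log units; within the scatter), so the two groups cannot be told apart at this place on the shared core. With 3,4,5-trimethoxyphenyl held constant, methyl in place of oxolan-3-yl on an oxygen on an aromatic ring gives a 1.2-fold higher number from compound 1 to compound 3 (0.06 log units; within the scatter), so this second place shows no separation either. No independent data bear on these results.

The compounds shown leave open whether any group at either place can move the number beyond the scatter. A pyridine ring in place of 3,4,5-trimethoxyphenyl, or a longer chain carrying an amine in place of methyl on the oxygen, remains an open case.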